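Naphthalen-1-yl in place of phenyl on the amine arm

The source may report more compounds than this note shows. Statements on the series, on what has been measured and on what is new or still open speak of the compounds shown alone.

Compound 3 `O=S(=O)(NCCCNCc1ccccc1)c1cc(C(F)(F)F)cc(C(F)(F)F)c1` gives 14000 nM in a functional assay on Capan-2 cells (Homo sapiens) for inhibition, read by MTT assay, with a stated time of 72 h (a higher number here means a weaker inhibitor of growth, a lower number a stronger inhibitor of growth), the highest of the three numbers. Compound 1 `O=S(=O)(NCCCNCc1ccc(Cl)c(C(F)(F)F)c1)c1cc(C(F)(F)F)cc(C(F)(F)F)c1` gives 9100 nM in this assay, and the step between the two reads a 1.5-fold higher number from compound 1 to compound 3 (0.19 log units; within the scatter). Compound 2 `O=S(=O)(NCCCNCc1ccc(C(F)(F)F)cc1)c1cc(C(F)(F)F)cc(C(F)(F)F)c1` gives 2000 nM, and here the step reads a 7.0-fold higher number from compound 2 to compound 3 (0.85 log units; beyond the scatter). Compound 4 `O=S(=O)(NCCCNCc1cccc2ccccc12)c1cc(C(F)(F)F)cc(C(F)(F)F)c1` differs from compound 3 by naphthalen-1-yl in place of phenyl on a saturated chain carbon bound to an amine nitrogen. Going by the values given here, no measured step enlarges this arm by a second ring, so the bearing is indirect. The step of a 7.0-fold higher number from compound 2 to compound 3 (0.85 log units; beyond the scatter) shows that a substituent on the aromatic ring of this arm can lower the number modestly, while the step of a 1.5-fold higher number from compound 1 to compound 3 (0.19 log units; within the scatter) shows that another substitution pattern leaves the number unchanged within the scatter. Taken together, a modest fall is expected rather than none or a large one; the estimated step is a 2.3-fold lower number from compound 3 to compound 4 (0.37 log units; beyond the scatter). Compound 4 is therefore expected to give about 6000 nM in this assay, with a range from 2000 nM to 18000 nM.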

Compound 4, concentration for 50% growth inhibition: 2700 nM
For compound 4 the middle estimate is 2.2-fold (0.35 log units) above the measured one; the range from low to high includes it.
By their numbers in this assay, from the lowest: compounds 2 and 4 (each within the scatter of the next); then compounds 1 and 3 (each within the scatter of the next).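

In this assay, this position accepts a larger aromatic group of carbon only: naphthalen-1-yl in place of phenyl gives a 5.2-fold lower number from compound 3 to compound 4 (0.71 log units; beyond the scatter) and needs no substituent to do so. The unsubstituted second ring and the 4-(trifluoromethyl)phenyl arm stand level, with a 1.4-fold higher number from compound 2 to compound 4 (0.13 log units; within the scatter) as the step, while the change from the 4-chloro-3-(trifluoromethyl)phenyl arm gives a 3.4-fold lower number from compound 1 to compound 4 (0.53 log units; beyond the scatter) and keeps that arm on the weaker side. No accompanying measurement bears on why the second ring lowers the number.

As far as these compounds go, whether naphthalen-2-yl, a pyridine ring or a longer chain on the amine arm would hold this level remains open. Also open, from the compounds shown here alone, is whether a trifluoromethyl group on the naphthalen-1-yl ring would lower the number further.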